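The compounds below may be only part of what the source reports. "The series", "measured", "known", "first", "only" and "open" are said of these compounds alone.

- Compound 1 `CC(=O)N1CCc2c(C)c3c(n2-c2ccc(C(N)=O)c(c2)N[C@@H](C)[C@H](C)C1)CC(C)(C)CC3=O`: 0.05 h
- Compound 2 `Cc1c2c(n3c1CCN(C(=O)C(C)(C)N)C[C@@H](C)[C@H](C)Nc1cc-3ccc1C(N)=O)CC(C)(C)CC2=O`: 0.417 h
- Compound 3 `Cc1c2c(n3c1CCN(C(=O)C1(N)CC1)C[C@@H](C)[C@H](C)Nc1cc-3ccc1C(N)=O)CC(C)(C)CC2=O`: 0.0667 h

In an in vitro ADME assay on microsomes (Homo sapiens) for metabolic stability (a higher number here means that the compound lasts longer, a lower number that the compound disappears faster), compound 3 sits at the low end of these numbers, together with compound 1, as a 1.3-fold higher number from compound 1 to compound 3 (0.13 log units; within the scatter) shows. Compound 4 `Cc1c2c(n3c1CCN(C(=O)C1(N)CCCC1)C[C@@H](C)[C@H](C)Nc1cc-3ccc1C(N)=O)CC(C)(C)CC2=O` carries 1-aminocyclopentyl in place of 1-aminocyclopropyl on a carbonyl carbon.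

Swaps at this same place gave an 8.3-fold higher number from compound 1 to compound 2 (0.92 log units; beyond the scatter) and a 6.3-fold lower number from compound 2 to compound 3 (0.80 log units; beyond the scatter), so this group can shift the number modestly. Yet the small change in a 1.3-fold higher number from compound 1 to compound 3 (0.13 log units; within the scatter) shows that a new group need not do so, and no measured compound has the five-membered ring. A step within the scatter is therefore expected, with no firm direction. The expected change is a 1.2-fold higher number from compound 3 to compound 4 (0.08 log units; within the scatter). For compound 4, the estimated half-life is 0.08 h, with an expected range of 0.03 h to 0.3 h.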

Compound 4, half-life: 0.0667 h
Estimate against measurement, compound 4: 1.2-fold (0.08 log units) above, within the range that was stated.
By their numbers in this assay, from the lowest: compounds 1, 3 and 4 (each within the scatter of the next); then compound 2.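

In this assay the swap gives no change at the digits printed from compound 3 to compound 4 (within the scatter) so enlarging the ring at this position leaves the number in place, and a 1.3-fold higher number from compound 1 to compound 4 (0.13 log units; within the scatter) puts the larger ring level with methyl too. Only 1-amino-1-methylethyl stands apart, as a 6.3-fold lower number from compound 2 to compound 4 (0.80 log units; beyond the scatter) confirms, so an amine on this carbon does not by itself go with the higher number of compound 2. No measurement here explains why. Still open, on these data alone, is whether a 1-aminocyclohexyl group would stay level with the smaller rings, and whether a longer open chain, such as 1-amino-1-ethylpropyl, would match compound 2.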